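Compound 3 to compound 4: 2-chlorophenyl swap

The source may hold more compounds than are shown below. What is called first, only, known or untested is meant among the compounds shown, and "the series" means these compounds.

Values in a functional assay on Bel-7402 cells (Homo sapiens) for cytotoxicity, read by MTT assay, with a stated time of 72 h; a higher number here means a weaker inhibitor, a lower number a stronger inhibitor:
- compound 1 `C=C1C(=O)[C@@]23C(=O)OC[C@]4(C(=O)CCC(C)(C)[C@H]4C=O)[C@@H]2CC[C@@H]1[C@H]3OC(=O)c1ccc(C)cc1`: 1540 nM
- compound 2 `C=C1C(=O)[C@@]23C(=O)OC[C@]4(C(=O)CCC(C)(C)[C@H]4C=O)[C@@H]2CC[C@@H]1[C@H]3OC(=O)c1ccc(F)cc1`: 3750 nM
- compound 3 `C=C1C(=O)[C@@]23C(=O)OC[C@]4(C(=O)CCC(C)(C)[C@H]4C=O)[C@@H]2CC[C@@H]1[C@H]3OC(=O)c1ccc(Cl)cc1`: 3840 nM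

Compound 3 shares the top of the range with compound 2 (a 1.0-fold higher number from compound 2 to compound 3 (0.01 log units; within the scatter)) and stands clear of compound 1 (a 2.5-fold higher number from compound 1 to compound 3 (0.40 log units; beyond the scatter)). Compound 4 `C=C1C(=O)[C@@]23C(=O)OC[C@]4(C(=O)CCC(C)(C)[C@H]4C=O)[C@@H]2CC[C@@H]1[C@H]3OC(=O)c1ccccc1Cl` carries 2-chlorophenyl in place of 4-chlorophenyl on a carbonyl carbon. The nearest evidence is substituent exchange on an aromatic carbon, which gave modest steps (a 2.4-fold higher number from compound 1 to compound 2 (0.39 log units; beyond the scatter) and a 2.5-fold higher number from compound 1 to compound 3 (0.40 log units; beyond the scatter)) or none beyond the scatter (a 1.0-fold higher number from compound 2 to compound 3 (0.01 log units; within the scatter)). Within the data shown here, no measured pair shows a chlorine changing place, so the direction stays open and little or no shift is expected: a 1.1-fold lower number from compound 3 to compound 4 (0.04 log units; within the scatter) is the estimated step. For compound 4 the estimate is 3500 nM, with the expected range running from 1600 nM to 7500 nM.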

Compound 4, half-maximal inhibitory concentration: 2890 nM
The estimate for compound 4 lay 1.2-fold (0.08 log units) above the measured number, within the range that was stated.
By their numbers in this assay, from the lowest: compounds 1, 4, 2 and 3 (each within the scatter of the next, the first and the last beyond it).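

Moving the chlorine, with 2-chlorophenyl in place of 4-chlorophenyl on a carbonyl carbon, gives no step beyond the scatter in this assay (a 1.3-fold lower number from compound 3 to compound 4 (0.12 log units; within the scatter)). Compound 4 also lies within the scatter of compound 2 (a 1.3-fold lower number from compound 2 to compound 4 (0.11 log units; within the scatter)) and of compound 1 (a 1.9-fold higher number from compound 1 to compound 4 (0.27 log units; within the scatter)), although compound 1 and compound 2 lie beyond the scatter of each other. No measurement here bears on the reason for this result.

From the compounds shown here alone, whether an aminophenyl or a pyridine ring in place of the chlorophenyl would give a step beyond the scatter stays open.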